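The source may hold more compounds than are shown below. What is called first, only, known or untested is meant among the compounds shown, and "the series" means these compounds.

Measured values:
Compound 1 `Nc1ccccc1NC(=O)/C=C/c1ccc(CSc2ccc(Cl)cc2)cc1`: 1.94%
Compound 2 `Nc1ccccc1NC(=O)c1ccc(CSc2ccc(C(F)(F)F)cn2)cc1`: 11.5%
Compound 3 `COc1ccc(SCc2ccc(C(=O)Nc3ccccc3N)cc2)cc1`: 35%

In a functional assay on HeLa cells (Homo sapiens) for inhibition, read by CCK-8 assay, with a stated time of 72 h, tested at 2 uM (on this read-out lower numbers stand for less inhibition of growth and higher numbers for more inhibition of growth at the one concentration tested), compound 1 gives 1.94%, the lowest of the three numbers in hand. Compound 2 gives 11.5%, a number that lies within the scatter of the value of compound 1, so no order between these two can be read. Compound 3 gives 35%, which stands beyond the scatter above compound 1. For the measured compounds named here, compounds 2 and 3 differ from compound 1 in more than one place, so no single-point step between measured compounds is available, and none of the measured pairs speaks directly to the exchange that follows.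

Compound 4 `CCc1ccc(SCc2ccc(/C=C/C(=O)Nc3ccccc3N)cc2)cc1` differs from compound 1 in one place: ethyl in place of chloro on an aromatic carbon The exchange sits on an aromatic carbon of a six-membered aromatic ring of carbon only, para to a large group. Going by the values given here, with no measured pair bearing on this exchange, the expectation in this assay is a small step, not beyond the scatter, with no firm direction. Compound 4 is expected to give 8% in this assay, with a range of -8% to 28%. The step expected on this basis is a number 6.1 percentage points higher from compound 1 to compound 4 (within the scatter), within the scatter.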

Compound 4, percent growth inhibition at one concentration: 3.96%
Estimate against measurement, compound 4: 4 percentage points above; the range from low to high includes it.
By their numbers in this assay, from the lowest: compounds 1, 4 and 2 (each within the scatter of the next); then compound 3.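

In this assay, for the compounds shown here, ethyl in place of chloro on an aromatic carbon, para to a large group, gives a number 2 percentage points higher from compound 1 to compound 4 (within the scatter); this is the first single-place pair, and at this position it does not separate the two groups. The exchange replaces one chlorine atom with two carbon atoms, with no ring, charge, hydrogen-bond donor or hydrogen-bond acceptor on either side, and this difference leaves compound 1 and compound 4 indistinguishable at the one concentration tested. Nothing in hand bears on why the two groups read alike.

As far as these compounds go, it remains open whether an amine, a carboxylic acid or an alkyl chain longer than ethyl on the same aromatic carbon of the core of compound 1 would read apart from chloro and ethyl, so the reach of this result beyond these two groups is unknown. Also open, from the compounds shown here alone, is whether compound 1 and compound 4 would stay together at a higher concentration, where the pair might give numbers further from the bottom of the scale.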